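Biaryl sulfonamide series: pyrazole to thiophene exchange

A few compounds are considered here, and "the series" means these few. Any claim that something is new, unique, unknown or untested is made for them only; others in the source may bear on it.

Measured so far:
compound 1 `COc1ccc(N2C[C@@H](C)N[C@@H](C)C2)cc1NS(=O)(=O)c1ccc(-c2cncnc2)cc1`: 0.6
compound 2 `COc1ccc(N2C[C@@H](C)N[C@@H](C)C2)cc1NS(=O)(=O)c1ccc(-n2cccn2)cc1`: 0.8

Among the measured compounds shown here, in a functional assay for agonist activity at growth hormone secretagogue receptor type 1 (Homo sapiens), read by FLIPR (a higher number here means a larger maximal response, a lower number a smaller maximal response), compound 2 gives 0.8, the higher of the two values so far, and the nearest neighbour is compound 1 with 0.6. For the measured compounds named here, the only measured step is a number 0.20 higher from compound 1 to compound 2 (beyond the scatter), which swaps one aromatic ring for another on the same aromatic carbon of the shared core.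

Compound 3 `COc1ccc(N2C[C@@H](C)N[C@@H](C)C2)cc1NS(=O)(=O)c1ccc(-c2cccs2)cc1` differs from compound 2 in one place: thiophen-2-yl in place of 1H-pyrazol-1-yl on an aromatic carbon. The step from compound 1 to compound 2 bears on this change only loosely, as both exchange a small aromatic ring at that carbon; it was modest and beyond the scatter. Going by the values given here, no measured pair gives the thiophene ring itself, so the direction is uncertain. A step of a number 0.10 lower from compound 2 to compound 3 (within the scatter) is expected, within the scatter. Compound 3 is therefore estimated at 0.7, in the range 0.5 to 0.9.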

Compound 3, intrinsic activity: the largest response reached, as a fraction of the reference agonist's: 1
For compound 3 the middle estimate is 0.30 below the measured one, outside the stated range (above it).
By their numbers in this assay, from the lowest: compound 1; then compound 2; then compound 3.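

In this assay, thiophen-2-yl in place of 1H-pyrazol-1-yl gives a number 0.20 higher from compound 2 to compound 3 (beyond the scatter) and so shows that this aromatic carbon, para to a large group, still distinguishes between two five-membered aromatic rings. Thiophen-2-yl in place of pyrimidin-5-yl gives a number 0.40 higher from compound 1 to compound 3 (beyond the scatter) as the largest step in the series, and the three compounds now stand in a clear order at this position, with compound 3 at the top at 1 in this assay. Nothing at hand explains this order.

On these data alone, it remains open whether thiophen-3-yl or a plain phenyl ring would hold the response of compound 3. As far as these compounds go, it is also open how a non-aromatic group at this carbon, such as an amine or a carboxylic acid, would compare.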